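Removing one methoxy group from compound 2: an expectation

The source may report more compounds than this note shows. Statements on the series, on what has been measured and on what is new or still open speak of the compounds shown alone.

Compound 1, `CCOC(=O)[C@H](CCC(=O)O)NC(=O)c1ccc(CNc2nc3cc(N)cc(N)c3nc2-c2ccccc2)cc1`: in a functional assay on HCT-15 cells (Homo sapiens) for inhibition, read by sulforhodamine B assay, with a stated time of 48 h (on this read-out lower numbers stand for higher toxicity in this test and higher numbers for lower toxicity in this test), compound 1 gives < 100000 nM, a limit of the assay rather than a number.
Compound 2, `COc1ccc(CNc2nc3cc(N)cc(N)c3nc2-c2ccccc2)cc1OC`: in this assay compound 2 gives < 100000 nM, again a limit.
Compound 3, `COc1cc(CNc2nc3cc(N)cc(N)c3nc2-c2ccccc2)cc(OC)c1OC`: in this assay compound 3 gives < 50200 nM, also a limit.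

Compound 2 therefore stands only at a limit, and the other two values shown are limits as well. Within the data shown here, the single step between measured neighbours, a step that the two limits leave unreadable from compound 2 to compound 3, cannot be read because of the limit of < 100000 nM in this assay, at which 2 of the 3 values shown sit, and (the limit of < 50200 nM in this assay, at which 1 of the 3 values shown sits).

Compound 4 is `COc1ccc(CNc2nc3cc(N)cc(N)c3nc2-c2ccccc2)cc1`. Its difference from compound 2 is hydrogen in place of methoxy on an aromatic carbon. Among the measured compounds shown here, no measured step bears on this change in a readable way, so no direction and no size beyond the scatter can be expected in this assay. Compound 4 is estimated to sit at 60000 nM, within 15000 nM to 150000 nM, most probably reported as a limit again. The step this estimate implies, a step that the limit leaves unreadable from compound 2 to compound 4, is expected to be no larger than the scatter.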

Compound 4, concentration lethal to 50% of the cells: 75900 nM
Beside the measured number, compound 4's estimate is 1.3-fold (0.10 log units) below it; the range from low to high includes it.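

Compound 4 carries a number in this assay, but compound 2 stands only at a limit, so the step between compound 2 and compound 4 cannot be read. As far as these compounds go, whether hydrogen in place of methoxy changes toxicity in this assay, and in which direction, stays open.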